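A few compounds are considered here, and "the series" means these few. Any claim that something is new, unique, unknown or untested is made for them only; others in the source may bear on it.

Measured compounds in the series:

compound 1, `Nc1cc(-c2ccccc2CO)nc(NCc2ccccc2)n1`: "not active" (no number reported)
compound 2, `CC(O)c1ccccc1-c1nc(N)nc(NCc2ccccc2)n1`: "not active" (no number reported)
compound 3, `Nc1nc(NCc2ccccc2F)nc(-c2ccccc2CO)n1`: 4.27

In a functional assay on cells for positive allosteric modulation of G-protein coupled receptor 68 (Homo sapiens), read by a luciferase reporter and cAMP accumulation, with a stated time of 30 min, at pH 6.8 and pH 8.3, in the presence of a further agent that is not named here (a higher number here means a more potent compound, by a factor of ten per unit of this negative logarithm, a lower number a less potent compound), compound 1 comes back as "not active" (no number reported) and compound 2 as "not active" (no number reported), so no number exists for either. Going by the values given here, compound 3 carries the only number in this assay, 4.27, and is therefore the only point of reference. Compound 4, `Cc1ccc(CNc2nc(N)nc(-c3ccccc3CO)n2)cc1`, has not been measured. It differs from compound 3 by 4-methylphenyl in place of 2-fluorophenyl on a saturated chain carbon bound to a nitrogen on an aromatic ring. Among the compounds with values here, no step between measured compounds is available for this change; the expectation is a step about the size of the scatter, with no clear direction, and compound 4 is expected to sit close to compound 3 in this assay. Compound 4 is estimated at 4.3 with a range of 3.8 to 4.8, which corresponds to an expected step of a number 0.03 log units higher from compound 3 to compound 4 (within the scatter).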

Compound 4, negative logarithm of the antagonist equilibrium constant: 4.38
Compound 4: the middle estimate sits 0.08 log units below what was measured; measured number inside the range.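

In this assay, going by these compounds alone, the step of a number 0.11 log units higher from compound 3 to compound 4 (within the scatter) is the first that can be read. At this saturated chain carbon bound to a nitrogen on an aromatic ring, 4-methylphenyl and 2-fluorophenyl leave the two compounds within the scatter of each other, so the position tolerates this exchange, and no evidence on the cause is at hand.

Still open, going by these compounds, is how a carboxylic acid or an amine in place of 4-methylphenyl would read. Also open, on these data alone, is whether a longer chain at this place would leave the number where it stands.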